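The compounds below may be only part of what the source reports. "The series", "measured", "known", "first", "only" and "open" are said of these compounds alone.

Compound 1 is `CS(=O)(=O)c1ccc(C(=O)NCCC(=O)N2CCCc3ccccc32)cc1[N+](=O)[O-]`. In an assay on isolated protein for inhibition of thyroid hormone receptor beta (Homo sapiens), read by fluorescence polarization (on this read-out higher numbers stand for weaker inhibition and lower numbers for stronger inhibition), compound 1 gives > 60000 nM, and this is a limit of the assay rather than a measured number. Compound 2 is `CN(Cc1ccccc1)C(=O)C1CCN(C(=O)c2ccc(S(C)(=O)=O)c([N+](=O)[O-])c2)CC1` and was tested in the same way. In this assay compound 2 gives > 60000 nM, again a limit and not a number. Among the compounds with values here, compound 1 thus stands at the limit of > 60000 nM in this assay, at which 2 of the 2 values shown sit, so nothing among the measured results can be put in order of strength. Compound 3 is `CS(=O)(=O)c1ccc(C(=O)NCCC(=O)N2CCc3ccccc3C2)cc1[N+](=O)[O-]`, not yet tested. The change from compound 1 to compound 3 is 1,2,3,4-tetrahydroisoquinolin-2-yl in place of 1,2,3,4-tetrahydroquinolin-1-yl on a carbonyl carbon; the two compounds hold the same atoms, joined differently. Within the data shown here, no step between measured compounds exists to guide an expectation, and compound 1 offers only a limit. The step from compound 1 to compound 3 is expected to be a number no higher from compound 1 to compound 3 (the limit leaves the size open), that is, nothing beyond the usual scatter. For compound 3 in this assay the estimate is 60000 nM, with a range from 20000 nM to 200000 nM, and most likely the assay will again report only a limit.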

Compound 3, half-maximal inhibitory concentration: > 60000 nM
Compound 3: a limit, no number; the forecaster's own chance of this, stated with the estimate: 85%; the middle value lies on the limit itself.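

Compound 1 and compound 3 both give only a limit, not a number, in this assay, so no step between them can be read: the limit of > 60000 nM in this assay, at which 3 of the 3 values shown sit.

The compounds shown leave open how strongly any of them inhibits the receptor, and whether 1,2,3,4-tetrahydroisoquinolin-2-yl in place of 1,2,3,4-tetrahydroquinolin-1-yl makes any difference.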